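Aryl swap on the shared core: compound 1 to compound 4

The source may hold more compounds than are shown below. What is called first, only, known or untested is meant among the compounds shown, and "the series" means these compounds.

Compound 1 `CC(C)c1ccc(-c2nc(N)c3cc(CN4[C@H](C)CCC[C@@H]4C)sc3n2)o1` gives 140 nM in an assay on CHO-K1 cells for antagonist activity at adenosine receptor A1 (Homo sapiens), read by a beta-galactosidase reporter, with stated times of 15 min and 6 h (a lower number here means a stronger inhibitor, a higher number a weaker inhibitor), the lowest of the three numbers measured. Compound 2 `Nc1nc(-c2ccc(C(F)F)o2)nc2sc(CN3CCC(F)CC3)cc12` gives 1670 nM in this assay, and compound 3 `Nc1nc(-c2cocn2)nc2sc(CN3CC=CC3)cc12` gives 3900 nM; both gaps from compound 1 lie beyond the scatter. Compound 4 `C[C@@H]1CCC[C@H](C)N1Cc1cc2c(N)nc(-c3cccc(C#N)c3)nc2s1` differs from compound 1 by 3-cyanophenyl in place of 5-isopropylfuran-2-yl on an aromatic carbon. For the measured compounds named here, no pair of measured compounds isolates this change, so the expectation rests on compound 1 alone. A modest rise in the number is expected, the estimated step being a 2.1-fold higher number from compound 1 to compound 4 (0.33 log units; beyond the scatter), which may not clear the scatter. Compound 4 is estimated at 300 nM in this assay, with a range from 80 nM to 1200 nM.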

Compound 4, inhibition constant: 460 nM
Compound 4: the middle estimate sits 1.5-fold (0.19 log units) below what was measured, and the stated range covers the measured number.
By their numbers in this assay, from the lowest: compound 1; then compound 4; then compound 2; then compound 3.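

With the rest of compound 1 held fixed, 3-cyanophenyl in place of 5-isopropylfuran-2-yl gives a 3.3-fold higher number from compound 1 to compound 4 (0.52 log units; beyond the scatter) in this assay. For the compounds shown here, this is the only step that isolates this aromatic carbon, as compound 2 and compound 3 differ from compound 1 in more than one place, and it shows that a six-membered aromatic ring of carbon only is accepted here with a modest loss. No data on hand explain the step.

Open, going by these compounds, is whether the rise follows from the ring change or from the nitrile, which plain phenyl would separate. Also open, on these data alone, is whether the step holds with the side chains of compound 2 and compound 3.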